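The source may hold more compounds than are shown below. What is called first, only, known or untested is meant among the compounds shown, and "the series" means these compounds.

Three close relatives of one macrocyclic scaffold have been examined in a functional assay on HL-60 cells (Homo sapiens) for antiproliferative activity, read by MTT assay, with a stated time of 48 h; on this read-out lower numbers stand for stronger inhibition and higher numbers for weaker inhibition. Compound 1 `CC(C)=CCC[C@]1(C)/C=C/[C@@H](OC(=O)C=C(C)C)[C@](C)(O)/C=C/C(=O)/C(CN(C(C)C)C(C)C)=C\C1` gives 740 nM in this assay. Among the three numbers, compound 1 stands second highest. Its nearest neighbour, compound 3 `CC(C)=CCC[C@]1(C)/C=C/[C@@H](OC(=O)C=C(C)C)[C@](C)(O)/C=C/C(O)/C(C=O)=C\C1`, gives 240 nM, a lower number that lies beyond the usual scatter. Furthest away is compound 2 `CC(C)=CCC[C@]1(C)/C=C/[C@@H](OC(=O)C=C(C)C)[C@](C)(O)/C=C/C(=O)/C(C[Si](c2ccccc2)(c2ccccc2)C(C)(C)C)=C\C1`, which gives 14400 nM, a far higher number that also lies beyond the scatter. No two of these compounds differ in only one place, so none of these gaps can be tied to a single change.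

Compound 4 `CO/N=C/C1=C/C[C@](C)(CCC=C(C)C)/C=C/[C@@H](OC(=O)C=C(C)C)[C@](C)(O)/C=C/C1=O` has not yet been measured. It differs from compound 1 as follows: a group of 4 heavy atoms (2 carbon, 1 nitrogen, 1 oxygen; no ring) in place of a group of 8 heavy atoms (7 carbon, 1 nitrogen; no ring), on a double-bonded ring carbon The (diisopropylamino)methyl group leaves and a group of four heavy atoms with one double bond outside aromatic rings enters, on a double-bonded ring carbon of the shared core.

Going by the values given here, no measured pair shows this exact change, so the expectation rests only on the three numbers and the structural difference. The step from compound 1 to compound 4 is expected to be a modest one toward a lower number, a 1.9-fold lower number from compound 1 to compound 4 (0.27 log units; within the scatter), close to the edge of the scatter. Compound 4 is accordingly estimated at 400 nM, with a likely range from 120 nM to 1500 nM.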

Compound 4, half-maximal inhibitory concentration: 4760 nM
For compound 4 the middle estimate is 12-fold (1.08 log units) below the measured one; measured number outside the range, above it.
By their numbers in this assay, from the lowest: compound 3; then compound 1; then compound 4; then compound 2.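

Replacing the (diisopropylamino)methyl group with the entering group of four heavy atoms gives a 6.4-fold higher number from compound 1 to compound 4 (0.81 log units; beyond the scatter) in this assay and so lies beyond the usual scatter. Going by these compounds alone, this is the first gap that can be tied to a single place, the double-bonded ring carbon of the shared core, and it shows that the number in this read-out responds to what sits on that carbon, since the rest of the structure stays the same. Nothing available here explains this rise in the number.

A single step cannot separate the effect of removing the (diisopropylamino)methyl group from that of adding the entering group, nor show whether the size of the group or the presence of its particular atoms counts for more. A smaller amine such as dimethylaminomethyl, a ring amine such as morpholinomethyl, a simple hydroxymethyl group or a longer alkyl oxime chain on the same carbon would each help to show how far the result extends.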